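Ester variants of compound 3 in a whole-animal test

The compounds below may be only part of what the source reports. "The series", "measured", "known", "first", "only" and "open" are said of these compounds alone.

Compound 3 `CCCc1nc(C(C)(C)O)c(C(=O)OCOC(=O)OC(C)C)n1Cc1ccc(-c2ccccc2C(=O)O)cc1` gives 71% in a functional assay on the whole organism for inhibition, with Rattus norvegicus as the target, with a stated time of 3 h, at a dose of 1 mg/kg; on this read-out lower numbers stand for less inhibition and higher numbers for more inhibition at the one dose given (going by the name of the read-out). Compound 2 `CCCc1nc(C(C)(C)O)c(C(=O)OCc2coc(=O)o2)n1Cc1ccc(-c2ccccc2C(=O)O)cc1` gives 70%, within the scatter of compound 3, while compound 1 `CCCc1nc(C(C)(C)O)c(C(=O)O)n1Cc1ccc(-c2ccccc2C(=O)O)cc1` gives 42%, clearly lower. Compound 4 `CCCc1nc(C(C)(C)O)c(C(=O)OC2OC(=O)c3ccccc32)n1Cc1ccc(-c2ccccc2C(=O)O)cc1` differs from compound 3 by a group of 10 heavy atoms (8 carbon, 2 oxygen; one five-membered non-aromatic ring with 1 hetero atom, one six-membered aromatic ring of carbon only) in place of a group of 8 heavy atoms (5 carbon, 3 oxygen; no ring), on an oxygen next to a carbonyl group. Two kinds of measured step bear on this. Replacing hydrogen on the oxygen next to the carbonyl group gave modest gains, a number 28 percentage points higher from compound 1 to compound 2 (beyond the scatter) and a number 29 percentage points higher from compound 1 to compound 3 (beyond the scatter), whereas exchanging one such group for another gave a number 1 percentage points higher from compound 2 to compound 3 (within the scatter). Since the earlier exchange of groups gave only a number 1 percentage points higher from compound 2 to compound 3 (within the scatter), the step of a number 3 percentage points lower from compound 3 to compound 4 (within the scatter) is expected to stay within the scatter in this assay. Compound 4 is therefore estimated at 68%, with a range from 50% to 84%.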

Compound 4, a percentage reported as inhibition, in the whole organism at one dose (the size of the read-out at that dose, not a potency): 77%
For compound 4 the middle estimate is 9 percentage points below the measured one; the measured number falls inside the stated range.
By their numbers in this assay, from the lowest: compound 1; then compounds 2, 3 and 4 (each within the scatter of the next).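

In this assay this position on an oxygen next to a carbonyl group also accepts a group with a five-membered non-aromatic ring and a six-membered aromatic ring, which gives a number 6 percentage points higher from compound 3 to compound 4 (within the scatter) and a number 7 percentage points higher from compound 2 to compound 4 (within the scatter) in the two exchanges. The three groups therefore cannot be told apart, yet replacing hydrogen with the new group gives a number 35 percentage points higher from compound 1 to compound 4 (beyond the scatter) as the first large step. Nothing measured here explains this result. Still open, on these data alone, is how a plain ethyl group on this oxygen would read, and whether these differences hold at other doses and times.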